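The source may report more compounds than this note shows. Statements on the series, on what has been measured and on what is new or still open speak of the compounds shown alone.

In an assay on isolated protein for displacement of a labelled ligand from metabotropic glutamate receptor 5 (Homo sapiens), with a stated time of 60 min, tested at 1 uM (a lower number here means less inhibition, a higher number more inhibition at the concentration tested (going by the name of the read-out)), compound 1 `COc1ccc2ncc(S(=O)(=O)c3cccc(Cl)c3)c(N3CCC(C)CC3)c2c1` gives -3%. Compound 2 `CC1CCN(c2c(S(=O)(=O)c3cccc(Cl)c3)cnc3ccc(F)cc23)CC1` gives 92% in this assay, and compound 3 `Cc1ccc2ncc(S(=O)(=O)c3cccc(Cl)c3)c(N3CCC(C)CC3)c2c1` gives 91%. Compound 2 holds the highest of the three numbers: its nearest neighbour is compound 3, differing by a number 1 percentage points lower from compound 2 to compound 3 (within the scatter), which lies within the scatter, while the furthest is compound 1, where the step of a number 95 percentage points higher from compound 1 to compound 2 (beyond the scatter) is large, as is a number 94 percentage points higher from compound 1 to compound 3 (beyond the scatter). All three steps change the group on the shared core, with fluoro or methyl in place of methoxy on an aromatic carbon. Compound 4 `Cc1ccc(S(=O)(=O)c2cnc3ccc(F)cc3c2N2CCC(C)CC2)cc1` arises from compound 2 by a change in a different place: 4-methylphenyl in place of 3-chlorophenyl on a sulfonyl sulfur. For the measured compounds named here, the group on the sulfonyl sulfur is the same 3-chlorophenyl in compound 1, compound 2 and compound 3, so no measured step bears on this change, and the data give no size or direction to expect. Compound 4 is therefore expected to give 60%, with a range from 10% to 95%, in this assay. That estimate means a number 32 percentage points lower from compound 2 to compound 4 (beyond the scatter), an expected fall that reflects uncertainty rather than any shown trend.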

Compound 4, a percentage reported as inhibition, at one concentration (the size of the read-out at that concentration, not a potency): 91%
Beside the measured number, compound 4's estimate is 31 percentage points below it; the measured number falls inside the stated range.
By their numbers in this assay, from the lowest: compound 1; then compounds 3, 4 and 2 (each within the scatter of the next).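

Putting 4-methylphenyl in place of 3-chlorophenyl on the sulfonyl sulfur gives a number 1 percentage points lower from compound 2 to compound 4 (within the scatter) in this assay. For the compounds shown here, this is the first look at this position, and it shows that, with fluoro on the shared core, the chlorine is not needed for a high number, since a ring of carbon only with a methyl group serves as well at the one concentration tested. Nothing available explains why the two groups read alike.

From the compounds shown here alone, both numbers are high readings at a single concentration, so a real difference in potency between the two could remain hidden, and it is open whether 4-methylphenyl would change the picture on the methoxy core of compound 1, which gives -3%. Also open, going by these compounds, is how a phenyl ring carrying a carboxylic acid or an amine would read on the sulfonyl sulfur.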